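Series notes: thioether swap to enamine piperazine at compound 4

The source may report more compounds than this note shows. Statements on the series, on what has been measured and on what is new or still open speak of the compounds shown alone.

Compound 3 `Cn1ccnc1SCC(=O)Nc1ccc(-c2nc(-c3ccccc3)c(-c3ccccc3)n2C)cc1` stands lowest of the three measured compounds in a functional assay on HT-29 cells (Homo sapiens) for cytotoxicity, read by MTT assay, with a stated time of 24 h, tested at 32 ug/mL (on this read-out higher numbers stand for a stronger effect at the one concentration tested and lower numbers for a weaker effect), where compound 3 gives 41.1%. Compound 1 `Cn1c(-c2ccc(NC(=O)CSc3nc4ccccc4s3)cc2)nc(-c2ccccc2)c1-c1ccccc1` gives 66% and compound 2 `Cn1cnnc1SCC(=O)Nc1ccc(-c2nc(-c3ccccc3)c(-c3ccccc3)n2C)cc1` gives 86.1%. The steps of a number 24.9 percentage points lower from compound 1 to compound 3 (beyond the scatter) and a number 45 percentage points lower from compound 2 to compound 3 (beyond the scatter) both lie beyond the scatter, so compound 3 is the weakest of the three, while a number 20.1 percentage points higher from compound 1 to compound 2 (beyond the scatter) separates the other two.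

Compound 4 `CN(C)/C=C/N1CCN(CC(=O)Nc2ccc(-c3nc(-c4ccccc4)c(-c4ccccc4)n3C)cc2)CC1` differs from compound 3 in one place: 4-(2-(dimethylamino)ethenyl)piperazin-1-yl in place of (1-methyl-1H-imidazol-2-yl)sulfanyl on a saturated chain carbon bound to a carbonyl carbon.

Among the measured compounds shown here, no measured step bears directly on this change. All three measured steps exchange one ring for another on the sulfur, whereas in compound 4 the whole (1-methyl-1H-imidazol-2-yl)sulfanyl group leaves and 4-(2-(dimethylamino)ethenyl)piperazin-1-yl enters on the saturated chain carbon bound to the carbonyl carbon. What the measured steps do show is that this position moves the read-out a great deal, a number 45 percentage points lower from compound 2 to compound 3 (beyond the scatter) being the largest. A step of either sign in this assay is therefore plausible and its direction cannot be read from the data. The working expectation is that compound 4 falls somewhere inside the measured spread, giving an estimated 55% with a wide range from 25% to 85%. This estimate corresponds to a step of a number 13.9 percentage points higher from compound 3 to compound 4 (beyond the scatter), which should be taken as uncertain.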

Compound 4, a percentage reported as activity, at one concentration (the size of the read-out at that concentration, not a potency): 29.8%
Beside the measured number, compound 4's estimate is 25.2 percentage points above it, within the range that was stated.
By their numbers in this assay, from the lowest: compound 4; then compound 3; then compound 1; then compound 2.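

Replacing the whole sulfur-linked group with 4-(2-(dimethylamino)ethenyl)piperazin-1-yl on the saturated chain carbon bound to a carbonyl carbon lowers the read-out in this assay relative to every earlier compound, modestly against one (a number 11.3 percentage points lower from compound 3 to compound 4 (beyond the scatter)) and by large steps against the other two (a number 36.2 percentage points lower from compound 1 to compound 4 (beyond the scatter) and a number 56.3 percentage points lower from compound 2 to compound 4 (beyond the scatter)). The earlier steps shown here exchanged only the ring on the sulfur and went in both directions, whereas this first change of the sulfur itself leaves compound 4 as the weakest of the four. No available data explain this fall.

Still open, from the compounds shown here alone, is which part of the change carries the loss, since the sulfur, the aromatic ring, the piperazine and the dimethylaminoethenyl tail all change in one step, and a plain piperazine, a morpholine or a simple dimethylamino group on the same carbon would help to separate them. Also open, going by these compounds, is whether the sulfur matters in itself, a question that an oxygen or methylene link carrying the 4-methyl-4H-1,2,4-triazol-3-yl ring of compound 2 would address.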